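Swapping a Cyclopentyl Amine for a Fluorophenyl Amine

The source may hold more compounds than are shown below. What is called first, only, known or untested is meant among the compounds shown, and "the series" means these compounds.

Compound 1 `COc1ccccc1NC1=CC(=O)c2c(nc3n2[C@H]2OC[C@@H](O)[C@H]2OC3)C1=O` gives 1670 nM in a functional assay on MGC-803 cells (Homo sapiens) for inhibition, read by sulforhodamine B assay; a lower number here means a stronger inhibitor, a higher number a weaker inhibitor.
Compound 3 `O=C1C(Nc2ccc(C(F)(F)F)cc2)=CC(=O)c2c1nc1n2[C@H]2OC[C@@H](O)[C@H]2OC1` gives 1860 nM.
For compound 2 `O=C1C=C(NC2CCCC2)C(=O)c2c1nc1n2[C@H]2OC[C@@H](O)[C@H]2OC1` only a limit is reported, > 8000 nM.

All three share the same core and differ only in the group on an amine nitrogen. Going by the values given here, the one measured step, a 1.1-fold higher number from compound 1 to compound 3 (0.05 log units; within the scatter), shows that two different aryl groups on that nitrogen give numbers within the scatter of each other. Among the compounds with values here, compound 2, carrying cyclopentyl, stands apart: its result is a limit of the assay and not a number, and it is the one value among the three that sits at the limit of > 8000 nM in this assay, at which 1 of the 3 values shown sits.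

Compound 4 `O=C1C=C(Nc2cccc(F)c2)C(=O)c2c1nc1n2[C@H]2OC[C@@H](O)[C@H]2OC1` is not yet measured. It differs from compound 2 by 3-fluorophenyl in place of cyclopentyl on an amine nitrogen. This brings compound 4 to the aryl-bearing pattern of compounds 1 and 3, whose values lie close together. Compound 4 is therefore expected to land near those two, estimated at 1800 nM, within a range of 900 nM to 3600 nM. From the limit of compound 2 this implies an expected step of an at least 4.4-fold lower number from compound 2 to compound 4 (0.64 log units; beyond the scatter) toward a stronger inhibitor.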

Compound 4, half-maximal inhibitory concentration: 2180 nM
Compound 4: the middle estimate sits 1.2-fold (0.08 log units) below what was measured, and the stated range covers the measured number.
By their numbers in this assay, from the lowest: compounds 1, 3 and 4 (each within the scatter of the next). At a limit, above all of these: compound 2.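

In this assay, going by these compounds alone, 3-fluorophenyl in place of cyclopentyl is the first single change here that links a non-aromatic ring to an aromatic ring on this amine nitrogen, and it gives an at least 3.6-fold lower number from compound 2 to compound 4 (0.56 log units; beyond the scatter). With 3-fluorophenyl joining 2-methoxyphenyl and 4-(trifluoromethyl)phenyl, all three aryl compounds now lie within the scatter of each other, so among these compounds the different groups on the aryl ring make no readable difference. Compound 2 remains a limit of the assay and not a number: the limit of > 8000 nM in this assay, at which 1 of the 4 values shown sits.

On these data alone, the true size of the gap between compound 2 and compound 4 therefore stays unknown. Cyclopentyl is also the only non-aromatic group shown, so it remains open whether a benzyl group, a pyridyl ring or a straight butyl chain on this nitrogen would read like the aryl compounds or like compound 2.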